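This account rests on a few compounds, and the source may have more. Where it says the series, first, only, none or still open, it means among the compounds named here.

Compound 1 `C=CS(=O)(=O)N1CCN(c2ncnc3sc(-c4cn(C)nc4C(F)(F)F)cc23)CC1`: 15100 nM
Compound 2 `C=CS(=O)(=O)N1CCN(c2nc(OC[C@H]3CCCN3C)nc3sccc23)CC1`: > 50000 nM (a limit)
Compound 3 `CN1CCN(c2ccc(-c3cc4c(N5CCN(S(=O)(=O)C6CC6)CC5)ncnc4s3)cc2)CC1`: 10600 nM

All three compounds were tested in a functional assay on MDA-MB-436 cells (Homo sapiens) for antiproliferative activity, read by MTT assay, with a stated time of 48 h; on this read-out lower numbers stand for stronger inhibition and higher numbers for weaker inhibition. Compound 2 gives only a limit, not a number. Compound 3 at 10600 nM and compound 1 at 15100 nM lie within the usual scatter of each other, so these two cannot be told apart.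

Compound 4 `CN1CCN(c2ccc(-c3cc4c(N5CCN(C(=O)Nc6ccccc6F)CC5)ncnc4s3)cc2)CC1` has (2-fluorophenyl)carbamoyl in place of cyclopropylsulfonyl on an amine nitrogen in a ring. Among the measured compounds shown here, no two measured compounds differ in one place only, so no measured step offers a guide to this change. The expected step is a 1.5-fold lower number from compound 3 to compound 4 (0.18 log units; within the scatter), which would not go beyond the scatter in this assay. For compound 4 the estimated value is 7000 nM, with an expected range of 1800 nM to 28000 nM.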

Compound 4, half-maximal inhibitory concentration: 14300 nM
For compound 4 the middle estimate is 2.0-fold (0.31 log units) below the measured one, and the stated range covers the measured number.
By their numbers in this assay, from the lowest: compounds 3, 4 and 1 (each within the scatter of the next). At a limit, above all of these: compound 2.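

In this assay, putting (2-fluorophenyl)carbamoyl in place of cyclopropylsulfonyl on an amine nitrogen in a ring gives a 1.3-fold higher number from compound 3 to compound 4 (0.13 log units; within the scatter), so compound 3 and compound 4 cannot be told apart. This position therefore takes a group with more heavy atoms, an aromatic ring and a hydrogen-bond donor without a step beyond the scatter. Nothing available here accounts for this result.

On these data alone, it remains open whether the fluorine matters, as a plain phenylcarbamoyl would show. An acetyl group or a free amine on this nitrogen also remains to be compared.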